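A few compounds are considered here, and "the series" means these few. Any claim that something is new, unique, unknown or untested is made for them only; others in the source may bear on it.

Measured compounds in an assay on THP-1 cells for displacement of a labelled ligand from C-C chemokine receptor type 1 (Homo sapiens); a higher number here means a weaker inhibitor, a lower number a stronger inhibitor:
compound 1, `Cc1ccc(C(=O)N[C@@H](C(=O)N2CCC(c3ccc(Cl)cc3)CC2)C(C)C)cc1`, gives 25 nM
compound 2, `CC(C)C(NC(=O)c1ccc2ccccc2c1)C(=O)N1CCC(c2ccc(Cl)cc2)CC1`, gives 80 nM
compound 3, `Cc1ccccc1C(=O)NC(CC(C)C)C(=O)N1CCC(c2ccc(Cl)cc2)CC1`, gives 88 nM

Compound 2 stands second highest of the three numbers. Its nearest neighbour is compound 3, whose value lies within the scatter of that of compound 2, so the two cannot be told apart here. The furthest is compound 1, whose value is beyond the scatter and so marks compound 1 as the stronger inhibitor of the pair.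

Compound 4, `CC(C)C(=O)NC(C(=O)N1CCC(c2ccc(Cl)cc2)CC1)C(C)C`, is not yet measured. It differs from compound 2 in one place: isopropyl in place of naphthalen-2-yl on a carbonyl carbon. Among the compounds with values here, no step between measured compounds involves this kind of change, so no direct comparison exists; all three measured compounds carry an aromatic ring on that carbonyl carbon, and none carries a chain there. The expectation is that the step from compound 2 to compound 4 in this assay goes upward, beyond the scatter, toward weaker inhibition, with a 10-fold higher number from compound 2 to compound 4 (1.00 log units; beyond the scatter) as the estimated size. Compound 4 is therefore estimated at 800 nM, with a range from 200 nM to 4000 nM.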

Compound 4, half-maximal inhibitory concentration: 388 nM
The estimate for compound 4 lay 2.1-fold (0.31 log units) above the measured number, and the stated range covers the measured number.
By their numbers in this assay, from the lowest: compound 1; then compounds 2 and 3 (each within the scatter of the next); then compound 4.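

In this assay, within the data shown here, a 4.9-fold higher number from compound 2 to compound 4 (0.69 log units; beyond the scatter) is the first reading of a group without a ring on the carbonyl carbon, and it marks a loss beyond the scatter on removing naphthalen-2-yl. The loss is not complete: with isopropyl at this place, compound 4 still gives 388 nM, so inhibition in this assay does not depend on an aromatic ring on that carbonyl carbon. No supporting data bear on why the step goes this way.

As far as these compounds go, this step rests on a single pair, so its size on other members remains unknown. From the compounds shown here alone, whether a cyclohexyl ring, a longer chain or a chain carrying an amine on the same carbonyl carbon would give a value closer to that of compound 2 or compound 4 also remains open.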